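From isopentyl to pentyl on the shared core

The source may hold more compounds than are shown below. What is called first, only, known or untested is meant among the compounds shown, and "the series" means these compounds.

compound 1 `[O-][n+]1nc(NCOCc2ccc(Cl)cc2)[n+]([O-])c2ccccc21` gives 8260 nM
compound 2 `COCNc1n[n+]([O-])c2ccccc2[n+]1[O-]` gives 9070 nM
compound 3 `CC(C)CCOCNc1n[n+]([O-])c2ccccc2[n+]1[O-]` gives 5210 nM

In a functional assay on KB cells (Homo sapiens) for cytotoxicity, read by MTT assay, with a stated time of 72 h (on this read-out higher numbers stand for weaker inhibition and lower numbers for stronger inhibition), compound 3 gives 5210 nM and the three numbers lie within the scatter of one another. Compound 4 `CCCCCOCNc1n[n+]([O-])c2ccccc2[n+]1[O-]` has not yet been measured. It differs from compound 3 in one place, propyl in place of isopropyl on a saturated chain carbon, two bonds along the chain from an oxygen on a saturated carbon with propyl in place of isopropyl on a saturated chain carbon, two bonds along the chain from an oxygen on a saturated carbon. Cut one bond further out, the same difference reads isopentyl to pentyl.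

Among the compounds with values here, no measured step exchanges a branched chain for a straight one, so the evidence is indirect. The nearest guides are changes to the same chain. Isobutyl in place of hydrogen gave a 1.7-fold lower number from compound 2 to compound 3 (0.24 log units; within the scatter) and isobutyl in place of 4-chlorophenyl gave a 1.6-fold lower number from compound 1 to compound 3 (0.20 log units; within the scatter) while hydrogen in place of 4-chlorophenyl gave a 1.1-fold higher number from compound 1 to compound 2 (0.04 log units; within the scatter) as well. With all of these inside the scatter, no step beyond it is expected in this assay here. The expected step is a 1.0-fold lower number from compound 3 to compound 4 (0.02 log units; within the scatter) and no direction can be favoured. For compound 4 the estimated value is 5000 nM with an expected range from 2600 nM to 9500 nM in this measurement.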

Compound 4, half-maximal inhibitory concentration: 39500 nM
Beside the measured number, compound 4's estimate is 7.9-fold (0.90 log units) below it, and the stated range ends below it.
By their numbers in this assay, from the lowest: compounds 3, 1 and 2 (each within the scatter of the next); then compound 4.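

In this assay, the change from isopentyl to pentyl, with propyl in place of isopropyl on a saturated chain carbon, two bonds along the chain from an oxygen on a saturated carbon, gives a 7.6-fold higher number from compound 3 to compound 4 (0.88 log units; beyond the scatter) even though the two compounds have the same atoms, joined differently. The earlier changes to this chain all stayed inside the scatter, whereas the straight chain also separates from the other two compounds, with a 4.4-fold higher number from compound 2 to compound 4 (0.64 log units; beyond the scatter) and a 4.8-fold higher number from compound 1 to compound 4 (0.68 log units; beyond the scatter), so this position proves responsive to how the chain is joined and not only to how much of it is present. Nothing at hand accounts for the difference.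

The compounds shown leave open whether the weaker inhibition belongs to straight chains in general, since a shorter straight propyl chain or a longer hexyl chain in this place could either stay near compound 4 or return to the level of the other three. They also leave open whether a branch placed elsewhere on the chain, as in a neopentyl group, or an amine at the chain end, would keep the level of compound 3.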